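Sulfonyl aryl exchange and hepatic extraction in microsomes

The source may report more compounds than this note shows. Statements on the series, on what has been measured and on what is new or still open speak of the compounds shown alone.

Measured so far:
compound 1 `Cc1ccccc1S(=O)(=O)N1CCN(c2cnc(C(=O)NCc3ccc(F)cc3)cn2)CC1` — 0.95
compound 2 `Cc1ccccc1S(=O)(=O)N1CC2(CN(c3ccc(C(=O)NCc4ccc(F)cc4)nn3)C2)C1` — 0.97

In an ADME assay on microsomes from liver (Homo sapiens), read by LC-MS, using NADPH, tested at 10 uM (on this read-out lower numbers stand for lower hepatic extraction and higher numbers for higher hepatic extraction), compound 1 gives 0.95. In this assay compound 2 gives 0.97. Among the measured compounds shown here, compound 2 carries the highest of the two numbers, yet its only neighbour, compound 1, sits a shade lower and inside the usual scatter, so no order between the two can be drawn; both simply sit near the top of the scale in this assay.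

Compound 3 `O=C(NCc1ccc(F)cc1)c1ccc(N2CC3(C2)CN(S(=O)(=O)c2cccnc2Cl)C3)nn1` is not yet measured. It differs from compound 2 in one place: 2-chloropyridin-3-yl in place of 2-methylphenyl on a sulfonyl sulfur

For the measured compounds named here, no pair of measured compounds in this set differs in a single place, so no measured step can be used as a guide. What is known is that compound 1 and compound 2, with unrelated differences between them, both give numbers at the high end of this assay. On that basis the step a number 0.050 lower from compound 2 to compound 3 (within the scatter) is expected to stay within the scatter, with any shift more likely downward than upward. For compound 3 the estimate is 0.92, in a range from 0.8 to 0.99.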

Compound 3, hepatic extraction ratio: 0.29
For compound 3 the middle estimate is 0.63 above the measured one; the whole stated range lies above it.
By their numbers in this assay, from the lowest: compound 3; then compounds 1 and 2 (each within the scatter of the next).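

The aryl group on the sulfonyl sulfur proves to be a highly sensitive place in this series: in this assay, 2-chloropyridin-3-yl in place of 2-methylphenyl gives a number 0.68 lower from compound 2 to compound 3 (beyond the scatter) on an otherwise unchanged structure. A read-out near the top of the scale is therefore not set by the remainder of compound 2 alone, since the same remainder in compound 3 carries a far lower hepatic extraction ratio with a group of equal heavy-atom count. Nothing available here bears on why this exchange has so large an effect.

As far as these compounds go, the exchange brings in a ring nitrogen and swaps methyl for chlorine at once, so the separate contribution of each remains open, and 2-chlorophenyl and 2-methylpyridin-3-yl on the same sulfonyl sulfur are the groups that would divide it. Also open, from the compounds shown here alone, is whether 2-chloropyridin-3-yl would have a comparable effect on the core of compound 1, as the step rests on a single matched pair.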